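Three inhibitors at the assay limit, and a pyridine analogue

This account rests on a few compounds, and the source may have more. Where it says the series, first, only, none or still open, it means among the compounds named here.

Compound 1, `N[C@@H]1CCCN(c2cc(Nc3ccccc3Cl)n3nccc3n2)C1`, gives in an assay on isolated protein for inhibition of Dipeptidyl peptidase 9 (Homo sapiens) (a lower number here means a stronger inhibitor, a higher number a weaker inhibitor), the value > 100000 nM, which is a limit of the assay and not a number.
Compound 2, `Clc1ccc(Nc2cc(N3CCNCC3)nc3ccnn23)c(Cl)c1`, gives in this assay the value > 100000 nM, again a limit.
Compound 3, `N[C@@H]1CCCN(c2cc(NCc3ccc(Cl)cc3Cl)n3nccc3n2)C1`, gives in this assay the value > 100000 nM, also a limit.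

Compound 1 therefore stands nowhere above or below its neighbours: all three sit at the limit of > 100000 nM in this assay, at which 3 of the 3 values shown sit, so no difference between them can be seen.

Compound 4, `N[C@@H]1CCCN(c2cc(Nc3cc(Cl)ccn3)n3nccc3n2)C1`, differs from compound 1 by one change: 4-chloropyridin-2-yl in place of 2-chlorophenyl on a nitrogen on an aromatic ring. For the measured compounds named here, no measured step exists for this change. Because every value shown sits at the limit of > 100000 nM in this assay, at which 3 of the 3 values shown sit, the step of a number no higher from compound 1 to compound 4 (the limit leaves the size open) is expected to stay within the scatter, most likely as a further limit. Compound 4 is thus estimated at 100000 nM, with a range from 30000 nM to 300000 nM.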

Compound 4, half-maximal inhibitory concentration: > 50000 nM
Compound 4: no number, only a limit; the forecaster's own chance of this, stated with the estimate: 80%; the middle value lies beyond the limit too.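

For the compounds shown here, compound 4 gives > 50000 nM, a limit and not a number; compound 1 also stands only at a limit, so no step between compound 1 and compound 4 can be read. The compounds shown leave open how strongly any of them inhibits in this assay.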